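The source may report more compounds than this note shows. Statements on the series, on what has been measured and on what is new or still open speak of the compounds shown alone.

Measured set:
Compound 1 `COc1ccc(-c2ncnn2-c2cc(OC)c(OC)c(OC)c2)cc1`: in a functional assay on K562 cells (Homo sapiens) for antiproliferative activity, read by MTT assay, with a stated time of 72 h (on this read-out higher numbers stand for weaker inhibition and lower numbers for stronger inhibition), compound 1 gives 950 nM.
Compound 2 `COc1cc(-n2ncnc2-c2ccccc2)cc(OC)c1OC`: in this assay compound 2 gives only the limit > 10000 nM.
Compound 3 `COc1cc(-n2ncnc2-c2ccc(Cl)c(Cl)c2)cc(OC)c1OC`: in this assay compound 3 gives only the limit > 10000 nM.

Compound 3 thus stands at the limit of > 10000 nM in this assay, at which 2 of the 3 values shown sit, with no number of its own; the steps of an at least 10-fold higher number from compound 1 to compound 2 (1.02 log units; beyond the scatter) and an at least 10-fold higher number from compound 1 to compound 3 (1.02 log units; beyond the scatter) show how far both limit compounds sit from compound 1, while a step that the two limits leave unreadable from compound 2 to compound 3 stays unreadable. Compound 4 `COc1cc(-n2ncnc2-c2ccc(SC)cc2)cc(OC)c1OC` differs from compound 3 as 4-(methylsulfanyl)phenyl in place of 3,4-dichlorophenyl on an aromatic carbon. Of the measured steps, an at least 10-fold higher number from compound 1 to compound 3 (1.02 log units; beyond the scatter) bears on this change, as it moved from 4-methoxyphenyl to 3,4-dichlorophenyl; a move to a 4-(methylsulfanyl)phenyl group is expected to recover part of that step, though a limit leaves the size uncertain. Compound 4 is therefore expected near 2000 nM, between 600 nM and 8000 nM, an expected step of an at least 5.0-fold lower number from compound 3 to compound 4 (0.69 log units; beyond the scatter).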

Compound 4, half-maximal inhibitory concentration: 340 nM
Estimate against measurement, compound 4: 5.9-fold (0.77 log units) above; the measured number lies below the stated range.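

In this assay, the 4-(methylsulfanyl)phenyl group gives a measurable value where phenyl and 3,4-dichlorophenyl do not, with an at least 29-fold lower number from compound 3 to compound 4 (1.46 log units; beyond the scatter) and an at least 29-fold lower number from compound 2 to compound 4 (1.46 log units; beyond the scatter). Both steps are measured against limits rather than numbers: the limit of > 10000 nM in this assay, at which 2 of the 4 values shown sit.

The substituent on this aryl group therefore decides the read-out, and methylsulfanyl also outperforms methoxy, with a 2.8-fold lower number from compound 1 to compound 4 (0.45 log units; beyond the scatter).

Open, on these data alone, is how a longer chain such as ethylsulfanyl, or an amine, would read in place of methylsulfanyl. As far as these compounds go, the size of the gain over compound 2 and compound 3 also remains open.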